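Notes on the amide-nitrogen extension from compound 3 to compound 4

This account rests on a few compounds, and the source may have more. Where it says the series, first, only, none or still open, it means among the compounds named here.

Measured so far in a functional assay on LNCaP cells (Homo sapiens) for antiproliferative activity; a higher number here means a weaker inhibitor, a lower number a stronger inhibitor:
compound 1 `CC(=O)NCC[C@@H]1C[C@@H](c2ccc(F)c(F)c2)[C@H](NC(=O)c2cc(-c3c(Cl)cnn3C)c(Cl)o2)CN1` gives 130 nM
compound 2 `CNC(=O)C[C@@H]1C[C@@H](c2ccc(F)c(F)c2)[C@H](NC(=O)c2cc(-c3c(Cl)cnn3C)c(Cl)o2)CN1` gives 50 nM
compound 3 `Cn1ncc(Cl)c1-c1cc(C(=O)N[C@@H]2CN[C@H](CC(N)=O)C[C@H]2c2ccc(Cl)c(Cl)c2)oc1Cl` gives 160 nM

Compound 3 gives the highest number of the three in this assay; its gap to compound 1 lies within the scatter, while compound 2 sits beyond it at a lower number. Among the compounds with values here, the only single-point step among the measured compounds, a 2.6-fold lower number from compound 1 to compound 2 (0.41 log units; beyond the scatter), concerns the chain that carries the amide and is modest in size.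

Compound 4 `Cn1ncc(Cl)c1-c1cc(C(=O)N[C@@H]2CN[C@H](CC(=O)NCCO)C[C@H]2c2ccc(Cl)c(Cl)c2)oc1Cl` differs from compound 3 by 2-hydroxyethyl in place of hydrogen on an amide-type nitrogen. Within the data shown here, no measured pair changes what sits on the amide-type nitrogen, so that step touches the same region but not the change itself. Among the measured compounds shown here, with no direct precedent, the expectation in this assay is a step that stays within the scatter, in no clear direction. The expected step is therefore a 1.1-fold lower number from compound 3 to compound 4 (0.03 log units; within the scatter), meaning none beyond the scatter. Compound 4 is estimated at 150 nM, with a range from 60 nM to 400 nM.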

Compound 4, half-maximal inhibitory concentration: 40 nM
Estimate against measurement, compound 4: 3.8-fold (0.57 log units) above; the whole stated range lies above it.
By their numbers in this assay, from the lowest: compounds 4 and 2 (each within the scatter of the next); then compounds 1 and 3 (each within the scatter of the next).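

In this assay, the amide-type nitrogen of the carbamoylmethyl chain accepts a substituent: 2-hydroxyethyl in place of hydrogen gives a 4.0-fold lower number from compound 3 to compound 4 (0.60 log units; beyond the scatter) and moves the number beyond the scatter. Within the data shown here, the earlier single-point step concerned the chain that carries the amide, so this is the first sign that what sits on the nitrogen itself can change the number in this assay. Nothing at hand accounts for the size or direction of this step.

As far as these compounds go, it remains open whether the gain requires the terminal hydroxyl or simply the added chain; ethyl, 2-methoxyethyl, 3-hydroxypropyl, or a chain ending in an amine or a carboxylic acid on the same nitrogen would separate these readings. From the compounds shown here alone, it is also open whether the same change holds with the aryl group carried by compound 1 and compound 2.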